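A Hydroxy Group Added to Compound 1

The source may hold more compounds than are shown below. What is called first, only, known or untested is meant among the compounds shown, and "the series" means these compounds.

Measured in a functional assay on the whole organism with Rattus norvegicus as the target; on this read-out lower numbers stand for an effect already at smaller amounts and higher numbers for an effect only at larger amounts of compound:
Compound 1 `CCOC(=O)C(=O)Nc1nc(-c2ccc(OC)cc2)cs1`: about 10 mg/kg.
Compound 2 `CCOC(=O)C(=O)Nc1nc(-c2ccc(Sc3ccccc3)cc2)cs1`: > 3 mg/kg, a limit.
Compound 3 `CCCC(=O)Nc1ccc(-c2csc(NC(=O)C(=O)OCC)n2)cc1`: > 10 mg/kg, a limit.

Compound 1 holds the only actual number among these three compounds, since the other two values are limits. Compound 4 `CCOC(=O)C(=O)Nc1nc(-c2ccc(OC)cc2O)cs1` keeps the whole of compound 1 and changes it in one place: hydroxy in place of hydrogen on an aromatic carbon. The new hydroxy takes the place of hydrogen on an aromatic carbon, ortho to a large group and meta to a methoxy group.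

The measured steps concern a different place, the methoxy group itself. Phenylsulfanyl there gives a step that the limit leaves unreadable from compound 1 to compound 2, and (propylcarbonyl)amino there gives a number no lower from compound 1 to compound 3 (the limit leaves the size open). Within the data shown here, neither step has a readable size, and no measured step adds a hydroxy group. No shift beyond the scatter is therefore expected in this assay, in either direction, and the expectation rests on compound 1 at about 10 mg/kg. The expected change is no change at the digits printed from compound 1 to compound 4 (within the scatter). For compound 4 the estimate is 10 mg/kg, with an expected range from 3 mg/kg to 30 mg/kg.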

Compound 4, dose for half-maximal effect: about 1 mg/kg
Compound 4: the middle estimate sits 10-fold (1.00 log units) above what was measured; measured number below the stated range.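

Unlike the changes at the methoxy group, whose steps cannot be read, hydroxy in place of hydrogen gives a readable result in this assay: a 10-fold lower number from compound 1 to compound 4 (1.00 log units; beyond the scatter). This shows that the aromatic carbon ortho to a large group and meta to a methoxy group is a place where adding a single oxygen atom to compound 1 moves the read-out toward effect at smaller amounts. The compounds shown offer nothing that explains this step.

From the compounds shown here alone, it remains open whether the gain belongs to hydroxy itself, or whether an amino group or a carboxylic acid on the same carbon would give a similar step. Going by these compounds, it is also open whether the same hydroxy would lower the number with phenylsulfanyl or (propylcarbonyl)amino in place of the methoxy group.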